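Shortening the alkoxy chain in the di-N-oxide series

A few compounds are considered here, and "the series" means these few. Any claim that something is new, unique, unknown or untested is made for them only; others in the source may bear on it.

Compound 2 `CCCCCOCNc1n[n+]([O-])c2ccccc2[n+]1[O-]` gives 1220 nM in a functional assay on KB cells (Homo sapiens) for cytotoxicity, read by MTT assay, with a stated time of 72 h; a lower number here means a stronger inhibitor, a higher number a weaker inhibitor; it stands second highest of the three numbers, with compound 3 `CCCCCOCNc1n[n+]([O-])c2cc(OC)ccc2[n+]1[O-]` at 2810 nM and compound 1 `COc1ccc2c(c1)[n+]([O-])nc(NCOC(C)c1ccccc1)[n+]2[O-]` at 220 nM. The change to compound 4 `CCCOCNc1n[n+]([O-])c2ccccc2[n+]1[O-]` is hydrogen in place of ethyl on a saturated chain carbon, three bonds along the chain from an oxygen on a saturated carbon. For the measured compounds named here, the only step touching this chain is a 13-fold higher number from compound 1 to compound 3 (1.11 log units; beyond the scatter), yet that swap exchanges an aryl-bearing group for an alkyl one, so it bears on the present change only loosely; the step of a 2.3-fold higher number from compound 2 to compound 3 (0.36 log units; beyond the scatter) concerns a different position. Going by the values given here, with no direct precedent for trimming pentyl to propyl, compound 4 is expected to sit close to compound 2, the step of a 1.2-fold higher number from compound 2 to compound 4 (0.09 log units; within the scatter) expected to stay near the scatter. In this assay compound 4 is estimated at 1500 nM, with a range from 600 nM to 4000 nM.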

Compound 4, half-maximal inhibitory concentration: 1950 nM
Compound 4: the middle estimate sits 1.3-fold (0.11 log units) below what was measured; measured number inside the range.
By their numbers in this assay, from the lowest: compound 1; then compounds 2, 4 and 3 (each within the scatter of the next, the first and the last beyond it).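

Pentyl to propyl now has a direct reading in this assay: a 1.6-fold higher number from compound 2 to compound 4 (0.20 log units; within the scatter), so taking ethyl off at this place on the chain leaves the number within the scatter. The larger shift on this side chain remains the aryl-for-alkyl exchange, a 13-fold higher number from compound 1 to compound 3 (1.11 log units; beyond the scatter), and no straight-chain trimming shown comes near it. No measurement at hand accounts for either step.

Open, going by these compounds, is whether a longer chain such as octyl, or a terminal amine on the propyl chain, would move the number. Also open, on these data alone, is whether propyl reads the same with methoxy on the core.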